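The source may report more compounds than this note shows. Statements on the series, on what has been measured and on what is new or still open speak of the compounds shown alone.

Of the compounds shown here, two built on one shared core have been measured in a functional assay on CHO-K1 cells with Glucose-dependent insulinotropic receptor (Homo sapiens) as the target, read by a luciferase reporter, with a stated time of 5 h; a lower number here means a smaller maximal response, a higher number a larger maximal response. Compound 1 `CC(C)OC(=O)N1CCC(Oc2ncnc3c2CCN3c2ccc(S(C)(=O)=O)cc2)CC1` reaches 154%. Compound 2 `CCCCOC(=O)N1CCC(Oc2ncnc3c2CCN3c2ccc(S(C)(=O)=O)cc2F)CC1` reaches 131%, the lower of the two numbers, and its gap to compound 1 lies beyond the usual scatter. Compound 3 `CC(C)SC(=O)N1CCC(Oc2ncnc3c2CCN3c2ccc(S(C)(=O)=O)cc2F)CC1` has not yet been measured; it differs from compound 2 in one place, (isopropylsulfanyl in place of butoxy on a carbonyl carbon). Among the compounds with values here, no measured pair shows this change, so there is no step to lean on. In this assay a step of a number 4 percentage points higher from compound 2 to compound 3 (within the scatter) is expected, small and of no clear direction. Compound 3 is accordingly estimated at 135%, within 105% to 165%.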

Compound 3, largest response reached (reported as percent of maximum), in percent of the reference or control that the assay uses: 138%
Compound 3: the middle estimate sits 3 percentage points below what was measured, within the range that was stated.
By their numbers in this assay, from the lowest: compounds 2 and 3 (each within the scatter of the next); then compound 1.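

Replacing butoxy with isopropylsulfanyl on the carbonyl carbon gives, in this assay, a number 7 percentage points higher from compound 2 to compound 3 (within the scatter). The two groups therefore cannot be told apart by maximal response, even though the atom attached to the carbonyl carbon is sulfur rather than oxygen and the group has one heavy atom fewer. Nothing measured here offers an explanation for this result.

On these data alone, how an amine such as isopropylamino, or a longer chain such as hexyloxy, would read on this carbonyl carbon remains open. Compound 1 differs from compound 2 in more than one place, so the effect of each difference also remains unresolved.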